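A few compounds are considered here, and "the series" means these few. Any claim that something is new, unique, unknown or untested is made for them only; others in the source may bear on it.

Compound 1, `COc1cc2cc(Oc3ccc(NC(=O)Nc4ccccc4)cc3)c(C)nc2cc1OC`, gives 63.4% in a functional assay on EKVX cells (Homo sapiens) for inhibition, read by sulforhodamine B assay, with a stated time of 48 h, tested at 10 uM; on this read-out lower numbers stand for a stronger effect and higher numbers for a weaker effect at the one concentration tested. Compound 2, `COc1cc2cc(Oc3ccc(NC(=O)Nc4ccc(C)cc4)cc3)c(C)nc2cc1OC`, gives 107%.

Compound 2 stands highest of the two numbers, above compound 1 by a number 43.6 percentage points higher from compound 1 to compound 2 (beyond the scatter). Compound 3, `COc1cc2cc(Oc3ccc(NC(=O)Nc4ccc(C(F)(F)F)cc4)cc3)c(C)nc2cc1OC`, differs from compound 2 by trifluoromethyl in place of methyl on an aromatic carbon. Going by the values given here, the one measured step, a number 43.6 percentage points higher from compound 1 to compound 2 (beyond the scatter), concerns a different change, so no measured step bears directly on this one. For compound 3 the expected step is therefore a number 12 percentage points lower from compound 2 to compound 3 (beyond the scatter), small and not clearly beyond the scatter. Compound 3 is expected to give about 95%, between 65% and 115%.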

Compound 3, a percentage reported as activity, at one concentration (the size of the read-out at that concentration, not a potency): 75.7%
Compound 3: middle estimate off by 19.3 percentage points, on the high side; the range from low to high includes it.
By their numbers in this assay, from the lowest: compound 1; then compound 3; then compound 2.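

In this assay, the group at this place, para to a large group, matters by its identity and not only by its presence: trifluoromethyl in place of methyl gives a number 31.3 percentage points lower from compound 2 to compound 3 (beyond the scatter) and so recovers much of the effect lost with methyl. Even so, trifluoromethyl does not match hydrogen, with a number 12.3 percentage points higher from compound 1 to compound 3 (beyond the scatter) remaining, so compound 1 keeps the lowest number of the three. Nothing available here explains this difference between the groups.

On these data alone, it remains open whether another group at this place, such as chlorine, methoxy or an amine, would bring the number below that of compound 1.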